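The source may hold more compounds than are shown below. What is called first, only, known or untested is meant among the compounds shown, and "the series" means these compounds.

Compound 1 `COc1ccc(-c2ccc3nnc([C@@H](C)c4ccc5ncccc5c4)n3n2)cc1F`: 281 mL.min-1.g-1
Compound 2 `C[C@@H](c1ccc2ncccc2c1)c1nnc2ccc(-c3ccccc3C#N)nn12`: 23.1 mL.min-1.g-1

These values come from an ADME assay on microsomes from liver (Homo sapiens) for metabolic stability, read by LC-MS, with a stated time of 30 min, tested at 1 uM; a higher number here means faster removal of the compound, a lower number slower removal. Compound 2 holds the lower of the two numbers, well clear of compound 1. The next compound, compound 3 `C[C@@H](c1ccc2ncccc2c1)c1nnc2ccc(-c3ccc(N(C)C)nc3)nn12`, has 6-(dimethylamino)pyridin-3-yl in place of 2-cyanophenyl on an aromatic carbon of the shared core: 6-(dimethylamino)pyridin-3-yl in place of 2-cyanophenyl on an aromatic carbon.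

For the measured compounds named here, only one measured step bears on this change: a 12-fold lower number from compound 1 to compound 2 (1.09 log units; beyond the scatter). It is a large step, and it came with the arrival of 2-cyanophenyl on that same core. Compound 3 gives up this group, so a move back towards compound 1 seems likely in this assay. A single step is a thin guide, however, and the new group has not been measured on this core, so the range must stay wide.

Compound 3 is estimated at 120 mL.min-1.g-1, within a range of 40 mL.min-1.g-1 to 320 mL.min-1.g-1. This expectation corresponds to a 5.2-fold higher number from compound 2 to compound 3 (0.72 log units; beyond the scatter).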

Compound 3, intrinsic clearance in microsomes: 232 mL.min-1.g-1
For compound 3 the middle estimate is 1.9-fold (0.29 log units) below the measured one; the range from low to high includes it.
By their numbers in this assay, from the lowest: compound 2; then compounds 3 and 1 (each within the scatter of the next).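

The change at this aromatic carbon in this assay is a 10-fold higher number from compound 2 to compound 3 (1.00 log units; beyond the scatter), so the low number of compound 2 does not carry over to the other new group placed there. For the compounds shown here, the comparison with the first compound gives a 1.2-fold lower number from compound 1 to compound 3 (0.08 log units; within the scatter), which puts 6-(dimethylamino)pyridin-3-yl and 3-fluoro-4-methoxyphenyl level, leaving 2-cyanophenyl as the only one of the three groups that stands apart. No available evidence accounts for this difference.

The compounds shown leave open whether the nitrile itself goes with the low number or whether the benzene ring carrying it also plays a part, a question that unsubstituted phenyl and 4-cyanophenyl on the same carbon could address. Also open, as far as these compounds go, is how a pyridin-3-yl group without the dimethylamino group would behave there.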